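The source may hold more compounds than are shown below. What is called first, only, known or untested is meant among the compounds shown, and "the series" means these compounds.

Measured compounds:
compound 1, `CCn1c(=O)[nH]c2ccc(OCCOc3ccc(Cl)cc3)cc21`, 7.24%
compound 2, `CCn1c(=O)[nH]c2ccc(OCCOc3cccc(F)c3)cc21`, 30.3%
compound 3, `CC(C)n1c(=O)[nH]c2ccc(OCCOc3ccc(Cl)cc3)cc21`, 18.2%

All three were tested in an assay on cells for inhibition of Amine oxidase [flavin-containing] B (Homo sapiens), read by fluorescence, with stated times of 30 min and 15 min, tested at 1 uM; on this read-out lower numbers stand for less inhibition and higher numbers for more inhibition at the one concentration tested (going by the name of the read-out). Compound 1 is the common starting point. Compound 2 differs from it by 3-fluorophenyl in place of 4-chlorophenyl on an oxygen on a saturated carbon, and this change gave a number 23.1 percentage points higher from compound 1 to compound 2 (beyond the scatter). Compound 3 differs from compound 1 by methyl in place of hydrogen on a saturated chain carbon bound to an aromatic nitrogen and a saturated chain carbon, which gave a number 11 percentage points higher from compound 1 to compound 3 (beyond the scatter). For the measured compounds named here, no step between compound 2 and compound 3 is broken down here; their values simply show compound 2 somewhat higher.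

Compound 4, `CC(C)n1c(=O)[nH]c2ccc(OCCOc3cccc(F)c3)cc21`, has not yet been measured in this assay. It differs from compound 3 by 3-fluorophenyl in place of 4-chlorophenyl on an oxygen on a saturated carbon, which is the same change, at the same place, as the one from compound 1 to compound 2; among these compounds the change occurs twice in all. Since the earlier instance of this change gave a number 23.1 percentage points higher from compound 1 to compound 2 (beyond the scatter), a step of similar size is expected from compound 3 to compound 4, namely a number 19.8 percentage points higher from compound 3 to compound 4 (beyond the scatter). Because compound 3 stands at 18.2%, compound 4 is estimated to reach 38%, expected to lie between 22% and 55%. Whether the second instance matches the first rests on a single prior pair only.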

Compound 4, a percentage reported as inhibition, at one concentration (the size of the read-out at that concentration, not a potency): 12.9%
For compound 4 the middle estimate is 25.1 percentage points above the measured one, outside the stated range (below it).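

In this assay, the swap to 3-fluorophenyl in place of 4-chlorophenyl did not behave alike on the two cores, giving a number 5.3 percentage points lower from compound 3 to compound 4 (within the scatter), and the two instances disagree: the same change on two cores in this assay, a number 23.1 percentage points higher (beyond the scatter) from compound 1 to compound 2 and a number 5.3 percentage points lower (within the scatter) from compound 3 to compound 4, 28.4 percentage points apart, beyond the scatter of two such steps
Seen from the other direction, methyl in place of hydrogen on the saturated chain carbon bound to the aromatic nitrogen gave a number 17.4 percentage points lower from compound 2 to compound 4 (beyond the scatter), and this step also departs from its earlier instance: the same change on two cores in this assay, a number 11 percentage points higher (beyond the scatter) from compound 1 to compound 3 and a number 17.4 percentage points lower (beyond the scatter) from compound 2 to compound 4, 28.4 percentage points apart, beyond the scatter of two such steps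
In these four compounds, then, the effect of either change depends on the other, so a step taken from one core cannot simply be carried to the next; the data do not show why this is so, and with a single pair per core and one tested concentration they cannot say how general it is.

The compounds shown leave open how other groups on the phenyl ring, such as a nitrile or a methoxy group, would behave on these two cores. They also leave open what a longer chain on the aromatic nitrogen would do to the same swap.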